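The source may hold more compounds than are shown below. What is called first, only, known or untested is meant among the compounds shown, and "the series" means these compounds.

Measured so far in a physicochemical assay for lipophilicity; a higher number here means a more lipophilic compound, a lower number a more polar compound:
- compound 1 `CCC1C(=O)N(C)c2cnc(-n3ccnc3-c3ccc(F)cc3)nc2N1c1ccc(F)cc1`: 3.4
- compound 2 `CC[C@@H]1C(=O)N(C)c2cnc(-n3ccnc3-c3ccccc3)nc2N1[C@H]1CCOC1`: 1.9

Compound 1 stands highest of the two, and compound 2 lies lower by more than the usual scatter. Compound 3 `CCC1C(=O)N(C)c2cnc(-n3ccnc3-c3ccc(F)cc3)nc2N1C1CCC(F)(F)C1` changes one group of compound 1: 3,3-difluorocyclopentyl in place of 4-fluorophenyl on a nitrogen on an aromatic ring in a ring. Going by the values given here, no two measured compounds differ in one place alone, so the expectation is a judgement: a small fall in this assay from compound 1 at 3.4, no larger than the scatter. The expected change is a number 0.30 log units lower from compound 1 to compound 3 (within the scatter). Compound 3 is estimated at 3.1, with an expected range of 2.6 to 3.5.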

Compound 3, partition coefficient: 3.1
Compound 3: the middle estimate sits on the measured number at the digits printed, and the stated range covers the measured number.
By their numbers in this assay, from the lowest: compound 2; then compounds 3 and 1 (each within the scatter of the next).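

In this assay, swapping the aromatic ring at this position for a non-aromatic one, with two fluorines in place of one, gives a number 0.30 log units lower from compound 1 to compound 3 (within the scatter). At this position, then, the two groups, which have the same heavy-atom count, cannot be told apart by this read-out. Nothing available explains why they read alike.

From the compounds shown here alone, it remains open whether a plain cyclopentyl ring, without its fluorines, or a ring carrying an amine or a carboxylic acid would also stay this close to compound 1. Compound 2 differs from compound 1 in more than one place, so it cannot settle this.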